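Trimming the alkoxy chain: from propoxy to methoxy

This account rests on a few compounds, and the source may have more. Where it says the series, first, only, none or still open, it means among the compounds named here.

Compound 1, `CCCCCOc1ccc(C(=O)c2cccc(Cn3ccnc3)c2)cc1`: 42 nM in an assay on isolated protein for inhibition of Aromatase (Homo sapiens), read by fluorescence, with stated times of 10 min and 60 min; on this read-out lower numbers stand for stronger inhibition and higher numbers for weaker inhibition
Compound 2, `CCCOc1ccc(C(=O)c2ccc(Cn3ccnc3)cc2)cc1`: 374 nM
Compound 3, `CCCOc1ccc(C(=O)c2cccc(Cn3ccnc3)c2)cc1`: 2 nM

Among these three, compound 3 stands with the lowest number in this assay, which on this read-out is the strongest inhibition; compound 1 is its nearest neighbour, and compound 2 lies furthest away. Compound 4, `COc1ccc(C(=O)c2cccc(Cn3ccnc3)c2)cc1`, has not yet been measured. It differs from compound 3 in one place only: hydrogen in place of ethyl on a saturated chain carbon bound to an oxygen on an aromatic ring, which is the same as saying propoxy becomes methoxy.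

Going by the values given here, only one measured step bears on this change, the one from compound 1 to compound 3, where the chain was also cut by two carbons: a 21-fold lower number from compound 1 to compound 3 (1.32 log units; beyond the scatter). Whether a second cut of the same kind continues in that direction cannot be read from a single step, and compound 2 does not help, because it differs in a different place. The expectation is therefore a modest step in this assay in either direction, most likely a 3.0-fold higher number from compound 3 to compound 4 (0.48 log units; beyond the scatter), with wide uncertainty. Compound 4 is estimated at 6 nM, in a range from 1.5 nM to 25 nM.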

Compound 4, half-maximal inhibitory concentration: 13 nM
Beside the measured number, compound 4's estimate is 2.2-fold (0.34 log units) below it, within the range that was stated.
By their numbers in this assay, from the lowest: compound 3; then compound 4; then compound 1; then compound 2.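

In this assay cutting propoxy down to methoxy gives a 6.5-fold higher number from compound 3 to compound 4 (0.81 log units; beyond the scatter) and so reverses the direction of the earlier step on this chain, which was a 21-fold lower number from compound 1 to compound 3 (1.32 log units; beyond the scatter) as the chain went from its longest form to propoxy. Shortening the chain therefore does not keep lowering the number, and among the three chains on this shared core propoxy gives the lowest number, with both the shorter and the longer chain giving higher ones. Methoxy still keeps a lower number than the longest chain, as a 3.2-fold lower number from compound 1 to compound 4 (0.51 log units; beyond the scatter) shows, so the change is not symmetrical around propoxy, and no evidence at hand gives a reason for this turn in the trend.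

What the compounds shown leave open is how an ethoxy or butoxy chain would behave at this place on the oxygen, and whether a chain ending in an amine or a carboxylic acid would fit the same trend. On these data alone, compound 2 also carries propoxy but differs elsewhere, so it remains open whether methoxy would move its number in the same direction.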